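This account rests on a few compounds, and the source may have more. Where it says the series, first, only, none or still open, it means among the compounds named here.

Compound 1, `C/C(=C\c1cc(-c2cccnc2)co1)C(N)=O`. In a functional assay on T-24 cells (Homo sapiens) for cytotoxicity, read by CCK-8 assay, with a stated time of 24 h (a lower number here means a stronger inhibitor, a higher number a weaker inhibitor), compound 1 gives > 50000 nM, a limit of the assay rather than a number.

Compound 2, `C/C(=C\c1cc(-c2ccc(C#N)cc2)cs1)C(N)=O`. In this assay compound 2 gives > 50000 nM, likewise a limit of the assay.

Going by the values given here, compound 2 therefore stands where every value so far stands: the limit of > 50000 nM in this assay, at which 2 of the 2 values shown sit. Among the compounds with values here, neither compound has a measured number, so no step between measured compounds can be described, and nothing in the data separates the two.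

Compound 3, `C=Cc1ccc(-c2csc(/C=C(\C)C(N)=O)c2)cc1`, is the next compound. It differs from compound 2 in one place: vinyl in place of cyano on an aromatic carbon, with the rest of the shared core unchanged. Within the data shown here, no measured pair shows what this exchange does in this assay, so there is no basis for expecting a step beyond the usual scatter in either direction. The most likely outcome is that compound 3 stays at the limit, as compound 2 does. Compound 3 is thus expected to give about 60000 nM, in a range from 20000 nM to 200000 nM. The step from compound 2 to compound 3 is expected to be a step that the limit leaves unreadable from compound 2 to compound 3.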

Compound 3, half-maximal inhibitory concentration: > 50000 nM
Compound 3 ended at the assay's limit; the forecaster's own chance of this, stated with the estimate: 85%; the middle value is on the limit's open side.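

Compound 2 and compound 3 both sit at a limit of the assay rather than at a number, so no step can be read for vinyl in place of cyano. The compounds shown leave open what any change to the shared core would do in this assay, because all of them give one reading: the limit of > 50000 nM in this assay, at which 3 of the 3 values shown sit.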